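This account rests on a few compounds, and the source may have more. Where it says the series, first, only, none or still open, it means among the compounds named here.

Measured so far in an assay on isolated protein for agonist activity at melatonin receptor type 1C (Xenopus laevis), read by spectrophotometry; a higher number here means that more compound is needed for the effect, a lower number that less compound is needed:
compound 1, `CCC(=O)NCc1ccc(F)c(OC)c1`, gives 2880 nM
compound 2, `COc1ccc(F)c(CCCNC(C)=O)c1`, gives 20.4 nM

Compound 2 stands at the lowest of the two numbers; compound 1 sits well beyond the scatter above it. Compound 3, `CCCC(=O)NCCCc1cc(OC)ccc1F`, is not yet measured and differs from compound 2 by one change: ethyl in place of hydrogen on a saturated chain carbon bound to a carbonyl carbon. Going by the values given here, no measured pair isolates this change, so the expected step is a guess. Lengthening an amide alkyl by this amount is expected to move this assay little, if anything toward a slightly lower number, so the step of a 1.4-fold lower number from compound 2 to compound 3 (0.13 log units; within the scatter) is estimated as small. For compound 3 the estimate in this assay is 15 nM, with a range of 4 nM to 60 nM.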

Compound 3, half-maximal effective concentration: 9.55 nM
The estimate for compound 3 lay 1.6-fold (0.20 log units) above the measured number, and the stated range covers the measured number.
By their numbers in this assay, from the lowest: compound 3; then compound 2; then compound 1.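

In this assay the saturated chain carbon bound to a carbonyl carbon accepts ethyl in place of hydrogen, turning acetyl into propylcarbonyl, and the change gives a 2.1-fold lower number from compound 2 to compound 3 (0.33 log units; beyond the scatter) as a modest step beyond the scatter. Going by these compounds alone, this is the first single-place reading at this position, and the added chain does not raise the number. Nothing on hand explains the drop.

Open, on these data alone, is whether a longer chain such as pentyl, a cyclopropyl ring or an amine at this carbon would lower the number further or reverse the step. Within the data shown here, the single step gives no direction beyond ethyl.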